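Replacing a long hydroxyalkyl ether with a short carboxy chain

The source may hold more compounds than are shown below. What is called first, only, known or untested is meant among the compounds shown, and "the series" means these compounds.

Compound 1 `O=c1c(-c2ccc(O)cc2)coc2cc(OCCCCCCCCCO)ccc12` carries a long hydroxyalkyl ether on the shared core. In an assay (Cricetulus griseus) for inhibition of Monoamine oxidase (Homo sapiens) (on this read-out lower numbers stand for stronger inhibition and higher numbers for weaker inhibition), compound 1 reaches only a limit, > 9000 nM, and so stands at the limit of > 9000 nM in this assay, at which 1 of the 3 values shown sits, rather than at a number. Compound 3 `CCCCC(Oc1ccc2c(=O)c(-c3ccc(O)cc3)coc2c1)C(=O)OCC` likewise gives only a limit in this assay, >> 9000 nM. Compound 2 `O=C(O)CCCCCOc1ccc2c(=O)cc(-c3ccc(O)cc3)oc2c1`, which carries a carboxy group at the end of its chain, gives a measured 7000 nM in this assay. Compound 4 `O=C(O)CCCCOc1ccc2c(=O)c(-c3ccc(O)cc3)coc2c1` differs from compound 1 by carboxy in place of 5-hydroxypentyl on a saturated chain carbon, four bonds along the chain from an oxygen on an aromatic ring. Within the data shown here, no measured step connects these two compounds. The change is expected to move the value little, if at all, beyond the scatter, at a number no higher from compound 1 to compound 4 (the limit leaves the size open). Compound 4 is therefore estimated at 9000 nM, within 3000 nM to 30000 nM, and may itself come back as a limit.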

Compound 4, half-maximal inhibitory concentration: 5000 nM
Compound 4: the middle estimate sits 1.8-fold (0.26 log units) above what was measured, within the range that was stated.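

In this assay carboxy in place of 5-hydroxypentyl, on a saturated chain carbon four bonds along the chain from an oxygen on an aromatic ring, gives an at least 1.8-fold lower number from compound 1 to compound 4 (0.25 log units; that floor lies within the scatter) and a measured number instead of a limit. The floor of this step does not show a gain beyond the scatter. Its true size stays unread because compound 1 stands only at a limit: the limit of > 9000 nM in this assay, at which 1 of the 4 values shown sits.

From the compounds shown here alone, whether a longer chain ending in a carboxylic acid, or an amine at the chain end, would move the number further remains open.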